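Switching a nitro for a methyl on a hydrazone cytotoxicity series

The compounds below may be only part of what the source reports. "The series", "measured", "known", "first", "only" and "open" are said of these compounds alone.

Measured so far:
- compound 1, `Cn1nnnc1SCC(=O)N/N=C/c1ccc(F)cc1`: 3160000 nM
- compound 2, `CN(C)c1ccc(/C=N/NC(=O)CSc2nnnn2C)cc1`: 100000 nM
- compound 3, `Cn1nnnc1SCC(=O)N/N=C/c1ccccc1[N+](=O)[O-]`: 1600000 nM

The three measured compounds share one core and differ only in the group on the aromatic ring at the far end. In a functional assay on A549 cells (Homo sapiens) for cytotoxicity, read by XTT assay, with a stated time of 24 h (a lower number here means a stronger inhibitor, a higher number a weaker inhibitor), compound 3 gives 1600000 nM, the second highest of the three numbers. Its nearest neighbour is compound 1, whose value of 3160000 nM lies within the scatter of that of compound 3, so the two cannot be told apart. Compound 2, with 100000 nM, sits furthest away and is clearly the stronger inhibitor of the three.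

The next compound, compound 4, `Cc1ccccc1/C=N/NC(=O)CSc1nnnn1C`, is made from compound 3 by one change: methyl in place of nitro on an aromatic carbon. Within the data shown here, the only step measured in this set, a 32-fold lower number from compound 1 to compound 2 (1.50 log units; beyond the scatter), concerns a different pair of groups and does not bear on a swap of nitro for methyl. Nothing measured here speaks to that exchange. The default expectation is then a step of no more than the scatter in this assay, in no particular direction. Compound 4 is therefore estimated at 1600000 nM, with a range from 500000 nM to 5000000 nM, corresponding to an expected step of no change at the digits printed from compound 3 to compound 4 (within the scatter).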

Compound 4, half-maximal inhibitory concentration: > 10000000 nM
Compound 4 gave a limit, no number (the forecaster's own chance of this, stated with the estimate: 20%); middle value at least 6.2-fold (0.79 log units) away from the limit.
By their numbers in this assay, from the lowest: compound 2; then compounds 3 and 1 (each within the scatter of the next). At a limit, above all of these: compound 4.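

This aromatic carbon, ortho to a large group, is sensitive to what it carries: methyl in place of nitro gives an at least 6.2-fold higher number from compound 3 to compound 4 (0.79 log units; beyond the scatter) in this assay. Among these compounds, the one earlier step concerned fluoro and dimethylamino, so it said nothing about this exchange, whereas this pair shows that replacing nitro with methyl moves the result towards weaker inhibition by more than the scatter. Compound 4 reaches a limit of the assay rather than a number, so the step gives only a minimum and its full size stays unknown: the limit of > 10000000 nM in this assay, at which 1 of the 4 values shown sits.

The two compounds compared here cannot show whether the value of compound 3 depends on nitro specifically, or whether other groups at this carbon would perform equally well. An amine, a carboxylic acid or a longer chain such as ethyl at this same carbon would help separate those possibilities, and methyl or nitro on a different carbon of the ring would show whether the position matters as much as the group.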